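This account rests on a few compounds, and the source may have more. Where it says the series, first, only, none or still open, it means among the compounds named here.

Three compounds share one core; compound 1 `CN1CC2(C1)CN(c1ccc(OCc3ccccc3)c(C(=O)Nc3ccnnc3)c1)C2` gives 25.1 nM in an assay on Sf9 cells for inhibition of Leucine-rich repeat serine/threonine-protein kinase 2 (Homo sapiens), read by TR-FRET, with stated times of 30 min and 2 h (a higher number here means a weaker inhibitor, a lower number a stronger inhibitor), compound 2 `O=C(Nc1ccnnc1)c1cc(N2CCC(F)CC2)ccc1OCc1ccccc1` gives 39.8 nM, and compound 3 `CN1CCC(c2ccc(OCc3ccccc3)c(C(=O)Nc3ccnnc3)c2)CC1` gives 20 nM. Compound 3 carries the lowest of the three numbers, yet all three sit within the scatter of each other, so no order among them is read. Compound 4 `O=C(Nc1ccnnc1)c1cc(N2CCC(CO)CC2)ccc1OCc1ccccc1` has not been measured; (4-(hydroxymethyl)piperidin-1-yl in place of 1-methylpiperidin-4-yl on an aromatic carbon). The nearest measured steps, a 2.0-fold lower number from compound 2 to compound 3 (0.30 log units; within the scatter) and a 1.3-fold lower number from compound 1 to compound 3 (0.10 log units; within the scatter), both swap a group on the same aromatic carbon and both stay within the scatter. For the measured compounds named here, no step here points to a larger effect of this change, so compound 4 is expected to land near compound 3, with an expected step of a 1.6-fold higher number from compound 3 to compound 4 (0.20 log units; within the scatter). The estimate for compound 4 is 32 nM, in the range 10 nM to 100 nM.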

Compound 4, half-maximal inhibitory concentration in the Leucine-rich repeat serine/threonine-protein kinase 2 assay: 20 nM
Compound 4: the middle estimate sits 1.6-fold (0.20 log units) above what was measured, and the stated range covers the measured number.
By their numbers in the Leucine-rich repeat serine/threonine-protein kinase 2 assay, from the lowest: compounds 3, 4, 1 and 2 (each within the scatter of the next).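

In the Leucine-rich repeat serine/threonine-protein kinase 2 assay the new group leaves the number unresolved from its neighbours: no change at the digits printed from compound 3 to compound 4 (within the scatter), a 2.0-fold lower number from compound 2 to compound 4 (0.30 log units; within the scatter) and a 1.3-fold lower number from compound 1 to compound 4 (0.10 log units; within the scatter). The earlier compounds shown here gave no second read-out; in a physicochemical assay for solubility, measured as kinetic solubility (on this read-out lower numbers stand for lower solubility and higher numbers for higher solubility), compound 3 gives 71000 nM and compound 4 gives 323000 nM. At this aromatic carbon, para to the benzyloxy group, 4-(hydroxymethyl)piperidin-1-yl in place of 1-methylpiperidin-4-yl separates the two compounds in the physicochemical assay but not in the Leucine-rich repeat serine/threonine-protein kinase 2 assay: the measured solubility of compound 3, 71000 nM, and of compound 4, 323000 nM, a 4.5-fold higher number (0.66 log units; beyond the scatter)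

Open, from the compounds shown here alone, is whether a carboxylic acid or a hydroxyethyl chain in place of hydroxymethyl would give the same picture in both read-outs.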